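Butylation of the chain on two related amide cores

This account rests on a few compounds, and the source may have more. Where it says the series, first, only, none or still open, it means among the compounds named here.

Compound 1 `CCCCCCCCNc1nccnc1C(=O)NCc1ccccc1` and compound 2 `CCCCNc1nccnc1C(=O)NCc1ccccc1` share one core and carry the same benzylamide, differing only in the length of the chain on the ring nitrogen. In an ADME assay on Vero cells (Chlorocebus sabaeus) for cytotoxicity, read by microscopy, with a stated time of 6 days (on this read-out higher numbers stand for lower toxicity in this test and lower numbers for higher toxicity in this test), compound 1 gives > 100000 nM, which is a limit of the assay and not a number. In this assay compound 2 likewise gives > 100000 nM, again a limit. The change between them is butyl in place of hydrogen on a saturated chain carbon, four bonds along the chain from a nitrogen on an aromatic ring, and the resulting step that the two limits leave unreadable from compound 2 to compound 1 cannot be read, because both ends sit at the limit of > 100000 nM in this assay, at which 2 of the 3 values shown sit.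

Compound 3 `CCCCNc1cncc(C(=O)NCc2ccccc2)n1` has the same atoms as compound 2 joined in a different core; the difference between the two cores is not broken down here. In this assay, going by the values given here, compound 3 gives 100000 nM, the single numeric reading in the set.

Compound 4 `CCCCCCCCNc1cncc(C(=O)NCc2ccccc2)n1` applies the same change to compound 3, namely (butyl in place of hydrogen on a saturated chain carbon, four bonds along the chain from a nitrogen on an aromatic ring), at a place worded identically to that between compound 2 and compound 1. Among the compounds with values here, since the one measured instance of this change left both ends at the ceiling of the assay, the step from compound 3 to compound 4 is expected to be no change at the digits printed from compound 3 to compound 4 (within the scatter), essentially flat. Compound 4 is therefore estimated at 100000 nM in this assay, most likely reported again as a limit, with an expected range from 50000 nM to 200000 nM.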

Compound 4, minimum cytotoxic concentration: > 100000 nM
Compound 4 gave a limit, no number; the forecaster's own chance of this, stated with the estimate: 65%; the middle value sits exactly at the limit.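

Compound 4 gives > 100000 nM in this assay, which is a limit of the assay and not a number. Butyl in place of hydrogen on a saturated chain carbon, four bonds along the chain from a nitrogen on an aromatic ring, thus gives a number no lower from compound 3 to compound 4 (the limit leaves the size open), so on this core, as on the core of compound 1 and compound 2, the change brings no reading of higher toxicity in this test. Going by these compounds, that is as far as the transfer between cores can be taken: neither step can be read as a size, and whether the change has the same magnitude on both cores stays unknown, because the values sit at the top of the measurable range: the limit of > 100000 nM in this assay, at which 3 of the 4 values shown sit.

The compounds shown leave open whether anything on the chain brings a numeric reading clearly under that ceiling on either core, a question that an amine or a carboxylic acid carried on the chain, or a longer chain, would address. On these data alone, the benzylamide is also the same throughout, and how these chain changes behave in any test other than this assay remains open.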